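Compound 3 in the methylamino to cyclopropylamino step

The compounds below may be only part of what the source reports. "The series", "measured", "known", "first", "only" and "open" are said of these compounds alone.

Measured in a functional assay on HT-29 cells (Homo sapiens) for inhibition; on this read-out lower numbers stand for stronger inhibition and higher numbers for weaker inhibition:
- compound 1 (`C[C@@]1(O)[C@@H](CO)OC(n2cnc3c(NC4CC4)ncnc32)[C@@H]1O`): > 100000 nM
- compound 2 (`CNc1ncnc2c1ncn2C1O[C@H](CO)[C@@H](O)[C@@]1(C)O`): > 100000 nM

Compound 2 stands at > 100000 nM in this assay, which is a limit of the assay and not a number. Compound 1, which carries a cyclopropylamino group, reads > 100000 nM, again a limit. The measured picture is therefore a single one: the limit of > 100000 nM in this assay, at which 2 of the 2 values shown sit. For the measured compounds named here, no numerical value and no measured step is available.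

Compound 3 (`C[C@]1(O)C(n2cnc3c(NC4CC4)ncnc32)O[C@H](CO)[C@H]1O`) has not yet been measured. It departs from compound 2 by cyclopropyl in place of methyl on a nitrogen on an aromatic ring.

Going by the values given here, with no measured step to draw on, no shift in either direction beyond the scatter is expected in this assay, and a reading at the limit is the likeliest outcome. The expected change is a number no higher from compound 2 to compound 3 (the limit leaves the size open) in this estimate. For compound 3 the estimated value is 100000 nM, with an expected range from 30000 nM to 200000 nM here.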

Compound 3, half-maximal inhibitory concentration: > 100000 nM
Compound 3 gave a limit, no number; the forecaster's own chance of this, stated with the estimate: 80%; the middle value sits exactly at the limit.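

Compound 2 and compound 3 both give a limit and not a number in this assay, and no step between them can be read: the limit of > 100000 nM in this assay, at which 3 of the 3 values shown sit.

The compounds shown leave open whether cyclopropyl in place of methyl on a nitrogen on an aromatic ring changes inhibition at all in this assay.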